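Working notes on the amine variation from compound 3

The source may hold more compounds than are shown below. What is called first, only, known or untested is meant among the compounds shown, and "the series" means these compounds.

Measured so far in an assay on HEK293 cells for inhibition of Steryl-sulfatase (Homo sapiens), tested at 1 uM; on this read-out higher numbers stand for a stronger effect at the one concentration tested and lower numbers for a weaker effect:
compound 1 `CN(CCCN1CCCCC1)c1ccc(C(=O)N2CCc3ccc(OS(N)(=O)=O)cc3C2)cc1` gives 40.7%
compound 2 `CCN(Cc1ccc(F)cc1)c1ccc(C(=O)N2CCc3ccc(OS(N)(=O)=O)cc3C2)cc1` gives 91.2%
compound 3 `CCCN(CCC)c1ccc(C(=O)N2CCc3ccc(OS(N)(=O)=O)cc3C2)cc1` gives 84.7%

On these numbers compound 3 stands second highest of three. Its nearest neighbour is compound 2, the step being a number 6.5 percentage points lower from compound 2 to compound 3 (within the scatter); its furthest is compound 1, with a number 44 percentage points higher from compound 1 to compound 3 (beyond the scatter). Compound 4 `CCN(Cc1ccncc1)c1ccc(C(=O)N2CCc3ccc(OS(N)(=O)=O)cc3C2)cc1` is not yet measured and differs from compound 3 in one place: ethyl((pyridin-4-yl)methyl)amino in place of dipropylamino on an aromatic carbon. Within the data shown here, the only measured step that bears on this change is a number 6.5 percentage points lower from compound 2 to compound 3 (within the scatter), where ethyl(4-fluorobenzyl)amino and dipropylamino gave numbers within the scatter. Among the measured compounds shown here, no measured step covers the pyridinyl ring itself. A step of no more than the scatter is therefore expected, a number 0.7 percentage points lower from compound 3 to compound 4 (within the scatter), and compound 4 is estimated at 84%, between 65% and 95%.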

Compound 4, a percentage reported as inhibition, at one concentration (the size of the read-out at that concentration, not a potency): 86.6%
Estimate against measurement, compound 4: 2.6 percentage points below, within the range that was stated.
By their numbers in this assay, from the lowest: compound 1; then compounds 3, 4 and 2 (each within the scatter of the next).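

In this assay, pyridin-4-yl in place of 4-fluorophenyl gives a number 4.6 percentage points lower from compound 2 to compound 4 (within the scatter), and ethyl((pyridin-4-yl)methyl)amino in place of dipropylamino gives a number 1.9 percentage points higher from compound 3 to compound 4 (within the scatter), so neither the ring nitrogen nor this swap separates these compounds. Among these compounds, the amine of compound 1 remains the one change that stands apart, with a number 45.9 percentage points higher from compound 1 to compound 4 (beyond the scatter). Nothing available explains these steps.

Open, from the compounds shown here alone, is whether a pyridin-3-yl ring or a carboxylic acid on the benzyl ring would hold the read-out. Also open, going by these compounds, is whether the piperidine or the propyl chain of compound 1 accounts for its separation.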